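Fluoro in place of chloro: a small step

The source may hold more compounds than are shown below. What is called first, only, known or untested is meant among the compounds shown, and "the series" means these compounds.

compound 1 `CC(C)c1nc2cc(Cl)c(Cl)cc2[nH]1` gives 52000 nM
compound 2 `Clc1cc2nc(-c3ccccc3Cl)[nH]c2cc1Cl` gives 23000 nM

Among the measured compounds shown here, both values come from a functional assay on HCT-116 cells (Homo sapiens) for cytotoxicity, read by MTT assay, with a stated time of 48 h (a lower number here means a stronger inhibitor of growth, a higher number a weaker inhibitor of growth), and are the only numbers so far. Compound 2 has the lower number, and the gap to compound 1 lies beyond the usual scatter. Compound 3 `Fc1ccccc1-c1nc2cc(Cl)c(Cl)cc2[nH]1` differs from compound 2 in one place (fluoro in place of chloro on an aromatic carbon): fluoro in place of chloro on an aromatic carbon. For the measured compounds named here, no measured pair shows this swap, so the guide is thin. Expected is a small 1.3-fold higher number from compound 2 to compound 3 (0.12 log units; within the scatter) toward weaker growth inhibition, probably within the scatter. For compound 3 the estimated value is 30000 nM with an expected range from 12000 nM to 70000 nM in this assay.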

Compound 3, concentration for 50% growth inhibition: 56500 nM
Beside the measured number, compound 3's estimate is 1.9-fold (0.27 log units) below it, within the range that was stated.
By their numbers in this assay, from the lowest: compound 2; then compounds 1 and 3 (each within the scatter of the next).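

Placing fluoro in place of chloro on this aromatic carbon, ortho to a large group, gives a 2.5-fold higher number from compound 2 to compound 3 (0.39 log units; beyond the scatter) in this assay, toward weaker growth inhibition. Among the compounds shown here, the earlier compounds offered no such pair, so this is the first sign that exchanging one heavy atom here can move the number beyond the scatter. Nothing available explains the shift.

Still open, on these data alone, is whether a methoxy group or an amine at this same position would give a lower or a higher number. As far as these compounds go, whether the same swap would act alike on another core also remains unknown.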